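This account rests on a few compounds, and the source may have more. Where it says the series, first, only, none or still open, it means among the compounds named here.

Working notes on the series. Compound 1 `Cc1ccnc(NC(=O)c2ccccc2C)c1` in a physicochemical assay for solubility, read by nephelometry, measured as kinetic solubility, at pH 6.5, tested at 10 mg/mL (a lower number here means a less soluble compound, a higher number a more soluble compound), gives 25 ug/mL. Compound 3 `Cc1ccccc1C(=O)Nc1cc(C#N)ccn1` gives 25 ug/mL in this assay, so compound 1 sits level with compound 3, its nearest neighbour, on the numbers shown. Compound 2 `Cc1cc(Br)ccc1C(=O)Nc1ccccn1` returns only a limit, > 100 ug/mL in this assay. That reading is the limit of > 100 ug/mL in this assay, at which 1 of the 3 values shown sits. The next compound, compound 4 `Cc1ccnc(NC(=O)c2cccc(F)c2C)c1`, differs from compound 1 by fluoro in place of hydrogen on an aromatic carbon. Going by the values given here, the one measured step, no change at the digits printed from compound 1 to compound 3 (within the scatter), concerned a different group and moved nothing beyond the scatter, and no measured step places a fluoro; no step beyond the scatter is therefore expected in this assay. Compound 4 is expected to give 22 ug/mL in this assay, between 8 ug/mL and 60 ug/mL. The estimated step is a 1.1-fold lower number from compound 1 to compound 4 (0.06 log units; within the scatter).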

Compound 4, solubility: 25 ug/mL
Beside the measured number, compound 4's estimate is 1.1-fold (0.06 log units) below it, within the range that was stated.
By their numbers in this assay, from the lowest: compounds 1, 3 and 4 (each within the scatter of the next). At a limit, above all of these: compound 2.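

In this assay, fluoro in place of hydrogen on the six-membered aromatic ring of carbon only, ortho to a methyl group, gives no change at the digits printed from compound 1 to compound 4 (within the scatter). Going by these compounds alone, this is the first measured step at this position and the first to place a fluoro, so a single fluorine atom here is tolerated with no reading beyond the scatter. No measurement shown gives a reason for this step. On these data alone, whether an amine, a carboxylic acid or a longer chain at this position would move the reading remains open. Fluoro at other positions on this ring also remains open.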